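The source may hold more compounds than are shown below. What is called first, only, known or untested is meant among the compounds shown, and "the series" means these compounds.

Among the compounds with values here, compound 2 `CC(Oc1ccc(CCC(=O)O)cc1)c1nc(-c2ccc(Cl)cc2)no1` stands at the lower end of the two numbers measured so far. Within the data shown here, in a functional assay on CHO cells for agonist activity at Free fatty acid receptor 1 (Homo sapiens), read by FLIPR and calcium flux, in the presence of a further agent that is not named here (on this read-out lower numbers stand for an effect already at smaller amounts and higher numbers for an effect only at larger amounts of compound), compound 2 gives 500 nM, and its only neighbour, compound 1 `CC(Oc1ccc(CCC(=O)O)cc1)c1nc(-c2ccccc2)no1`, gives 2390 nM in this assay. Among the measured compounds shown here, the one measured step, a 4.8-fold lower number from compound 1 to compound 2 (0.68 log units; beyond the scatter), is the sole comparison available.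

Compound 3 `CC(Oc1ccc(CCC(=O)O)cc1)c1nc(-c2cccs2)no1` carries the change (thiophen-2-yl in place of 4-chlorophenyl on an aromatic carbon). For the measured compounds named here, no measured pair shows this exchange directly; the step from compound 1 to compound 2 bears on it only in that it shows the ring on that carbon to be a place where a change moves the number in this assay. Since compound 3 gives up the chloro that separated compound 2 from compound 1, a higher number than that of compound 2 is expected, though the five-membered ring is a different substitution and the size of the shift is uncertain. The expected step is a 3.0-fold higher number from compound 2 to compound 3 (0.48 log units; beyond the scatter), and compound 3 is estimated to give 1500 nM in this assay, within a range from 500 nM to 4500 nM.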

Compound 3, half-maximal effective concentration: 4000 nM
Compound 3: the middle estimate sits 2.7-fold (0.43 log units) below what was measured; measured number inside the range.
By their numbers in this assay, from the lowest: compound 2; then compounds 1 and 3 (each within the scatter of the next).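

The exchange of 4-chlorophenyl for thiophen-2-yl on this aromatic carbon gives an 8.0-fold higher number from compound 2 to compound 3 (0.90 log units; beyond the scatter) in this assay and so shows that the low number of compound 2 does not carry over to this five-membered aromatic ring. Thiophen-2-yl in place of phenyl gives a 1.7-fold higher number from compound 1 to compound 3 (0.22 log units; within the scatter) and so, on this carbon between two ring nitrogen atoms, the two unsubstituted aromatic rings cannot be told apart on this read-out. Of the three groups seen at this position, only 4-chlorophenyl stands apart from the other two, and nothing given here accounts for that difference.

The compounds shown leave open whether the gain tied to the chloro on the phenyl ring depends on that ring or would also appear with a 5-chlorothiophen-2-yl group. They also leave open whether another substituent on the phenyl ring, such as methoxy or trifluoromethyl, or a pyridine ring in place of the phenyl ring, would keep the number of compound 2 or return it to the level shared by compound 1 and compound 3.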